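Trading the aromatic ring for a branched alkene

The compounds below may be only part of what the source reports. "The series", "measured", "known", "first", "only" and "open" are said of these compounds alone.

Compound 3 `O=C1CC(c2ccccc2OCc2cccc(F)c2)Oc2ccccc21` stands highest of the three numbers in a functional assay on RAW264.7 cells (Mus musculus) for inhibition, read by immunoassay, with a stated time of 12 h, tested at 30 uM (a lower number here means less inhibition, a higher number more inhibition at the concentration tested (going by the name of the read-out)), where compound 3 gives 93.3%. Compound 1 `O=C1CC(c2ccccc2OCc2ccccc2)Oc2ccccc21` gives 93.2%, and the step of a number 0.1 percentage points higher from compound 1 to compound 3 (within the scatter) lies within the scatter, so those two cannot be ranked. Compound 2 `C=CCOc1ccccc1C1CC(=O)c2ccccc2O1` gives 49.3%.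

The next compound, compound 4 `CC(C)=CCOc1ccccc1C1CC(=O)c2ccccc2O1`, differs from compound 3 by 2-methylprop-1-en-1-yl in place of 3-fluorophenyl on a saturated chain carbon bound to an oxygen on an aromatic ring. Among the measured compounds shown here, two measured steps bear on this change. Going a number 43.9 percentage points lower from compound 1 to compound 2 (beyond the scatter), a six-membered aromatic ring on that carbon was exchanged for a chain carrying a double bond, and inhibition fell sharply. Going a number 44 percentage points higher from compound 2 to compound 3 (beyond the scatter), the reverse exchange raised it by as much. Compound 4 again carries a chain with one double bond outside aromatic rings and no ring at that place, so a large drop in this assay is expected, roughly a number 41.3 percentage points lower from compound 3 to compound 4 (beyond the scatter). Compound 4 is therefore estimated at 52%, between 32% and 72%. Whether the longer chain of compound 4, set against the vinyl of compound 2, behaves any differently is not shown by the data.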

Compound 4, a percentage reported as inhibition, at one concentration (the size of the read-out at that concentration, not a potency): 41.8%
For compound 4 the middle estimate is 10.2 percentage points above the measured one; the range from low to high includes it.
By their numbers in this assay, from the lowest: compounds 4 and 2 (each within the scatter of the next); then compounds 1 and 3 (each within the scatter of the next).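

In this assay, a second chain with one double bond and no ring gives the same large loss seen with vinyl on the saturated chain carbon bound to an oxygen on an aromatic ring (a number 51.5 percentage points lower from compound 3 to compound 4 (beyond the scatter); a number 51.4 percentage points lower from compound 1 to compound 4 (beyond the scatter)). Against vinyl, 2-methylprop-1-en-1-yl brings no change that can be told apart (a number 7.5 percentage points lower from compound 2 to compound 4 (within the scatter)), so the two chains sit together, well under the phenyl and 3-fluorophenyl compounds. No measurement at hand explains why these groups differ in this way.

The compounds shown leave open whether a cyclohexyl group, a ring with no double bonds, would stand with the aromatic rings or with the chains. From the compounds shown here alone, how a saturated chain such as butyl, or a pyridine ring in place of the phenyl, would behave at this place also remains open.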